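The compounds below may be only part of what the source reports. "The series", "measured", "known", "first", "only" and "open" are said of these compounds alone.

Compound 1 (`C=CC(=O)N1CC(NC(=O)Cn2cc(C(=O)N3CCc4ccccc4C3)c3cc(Br)ccc32)C1`): in a physicochemical assay for pharmacokinetics, read by LC-MS, in phosphate buffer, at pH 7.4, in the presence of a further agent that is not named here (on this read-out lower numbers stand for a shorter-lived compound and higher numbers for a longer-lived compound), compound 1 gives 1.67 h.
Compound 2 (`C=CC(=O)N1CC(NC(=O)Cn2cc(C(=O)N3CCc4cc(Cl)ccc4C3)c3cc(Br)ccc32)C1`): in this assay compound 2 gives 1.67 h.
Compound 3 (`C=CC(=O)N1CC(NC(=O)Cn2cc(C(=O)N(C)Cc3ccccc3)c3cc(Br)ccc32)C1`): in this assay compound 3 gives 1.67 h.

Compound 2 stands level with compounds 1 and 3 on this assay: the step of no change at the digits printed from compound 1 to compound 2 (within the scatter), the step of no change at the digits printed from compound 1 to compound 3 (within the scatter) and the step of no change at the digits printed from compound 2 to compound 3 (within the scatter) all lie within the scatter of the method. Compound 4 (`C=CC(=O)N1CC(NC(=O)Cn2cc(C(=O)N3CCc4c(cccc4OC)C3)c3cc(Br)ccc32)C1`) has not yet been measured. It differs from compound 2 by a group of 12 heavy atoms (10 carbon, 1 nitrogen, 1 oxygen; one six-membered non-aromatic ring with 1 hetero atom, one six-membered aromatic ring of carbon only) in place of a group of 11 heavy atoms (9 carbon, 1 nitrogen, 1 chlorine; one six-membered non-aromatic ring with 1 hetero atom, one six-membered aromatic ring of carbon only), on a carbonyl carbon. Two of the measured steps bear directly on this kind of change, since both replace the group on the same carbonyl carbon: the step of no change at the digits printed from compound 1 to compound 3 (within the scatter) and the step of no change at the digits printed from compound 2 to compound 3 (within the scatter), neither of which moved the half-life beyond the scatter. The third step, no change at the digits printed from compound 1 to compound 2 (within the scatter), an exchange within the aromatic part of that group, was equally flat. On these three compounds the read-out has been indifferent to what sits on the carbonyl carbon, so the step of no change at the digits printed from compound 2 to compound 4 (within the scatter) is expected to stay within the scatter as well. Compound 4 is therefore estimated at 1.67 h, with a range from 0.9 h to 3.2 h.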

Compound 4, half-life: 1.67 h
Compound 4: the middle estimate sits on the measured number at the digits printed; low and high end bracket the measured number.
By their numbers in this assay, from the lowest: compounds 1, 2, 3 and 4 (each within the scatter of the next).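

The entering group brings an oxygen and a hydrogen-bond acceptor to this carbonyl carbon, which no earlier group carried, yet the step of no change at the digits printed from compound 2 to compound 4 (within the scatter) shows that this assay does not respond to them. The methoxy in place of hydrogen gives the same picture as the chloro did, with no change at the digits printed from compound 1 to compound 4 (within the scatter) standing alongside no change at the digits printed from compound 1 to compound 2 (within the scatter) as a flat step, so two different substituents on the aromatic part of this group now leave the half-life where it was in compound 1. The step of no change at the digits printed from compound 3 to compound 4 (within the scatter) adds that the open benzyl(methyl)amino group and this larger ring-bearing group also read alike, which widens the range of groups on this carbonyl carbon that give the same reading.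

The compounds shown leave open whether a carboxylic acid or a primary amine on this group would move the half-life, and whether a change on the shared core, away from this carbonyl carbon, would do so. No measurement at hand accounts for the flat readings across these four compounds.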